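A few compounds are considered here, and "the series" means these few. Any claim that something is new, unique, unknown or untested is made for them only; others in the source may bear on it.

In an assay on isolated protein for inhibition of B1 bradykinin receptor (Homo sapiens) (on this read-out lower numbers stand for stronger inhibition and higher numbers for weaker inhibition), compound 1 `Cc1ccc(S(=O)(=O)N2CCCC[C@H]2CC(=O)N[C@@H]2CCCc3cc(CNC(C)(C)C)ccc32)cc1Cl` gives 15 nM, compound 2 `O=C(C[C@@H]1CCCCN1S(=O)(=O)c1cccc(C(F)(F)F)c1)N[C@@H]1CCCc2cc(CNCC3CC3)ccc21` gives 16 nM, and compound 3 `O=C(C[C@@H]1CCCCN1S(=O)(=O)c1cccc(C(F)(F)F)c1)N[C@@H]1CCCc2cc(CNC3CC3)ccc21` gives 48 nM. Compound 3 therefore stands highest of the three numbers, meaning the weakest inhibition of the set. Its nearest neighbour is compound 2: the change of cyclopropyl in place of cyclopropylmethyl on an amine nitrogen produced a 3.0-fold higher number from compound 2 to compound 3 (0.48 log units; beyond the scatter). Compound 1 lies furthest from it, the two values differing by a little more than that.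

Compound 4 `O=C(C[C@@H]1CCCCN1S(=O)(=O)c1cccc(C(F)(F)F)c1)N[C@@H]1CCCc2cc(CN3CCC3)ccc21` is built from compound 3 by rearranging the same atoms: azetidin-1-yl in place of cyclopropylamino on a saturated chain carbon bound to an aromatic carbon. No measured step in this assay mirrors that change, so the only guide is the one shown step, which was modest. Compound 4 is therefore expected to land close to compound 3, with a step of a 1.2-fold lower number from compound 3 to compound 4 (0.08 log units; within the scatter) that need not exceed the scatter in either direction. For compound 4 the estimate in this assay is 40 nM, within a range from 12 nM to 150 nM.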

Compound 4, half-maximal inhibitory concentration: 1100 nM
For compound 4 the middle estimate is 28-fold (1.44 log units) below the measured one; the measured number lies above the stated range.
By their numbers in this assay, from the lowest: compounds 1 and 2 (each within the scatter of the next); then compound 3; then compound 4.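

In this assay, the azetidin-1-yl group in place of cyclopropylamino gives a 23-fold higher number from compound 3 to compound 4 (1.36 log units; beyond the scatter) even though both groups hold the same atoms, so at this position the way those atoms are joined matters far more than the earlier 3.0-fold higher number from compound 2 to compound 3 (0.48 log units; beyond the scatter) suggested. The gap is wider still against (cyclopropylmethyl)amino, with a 69-fold higher number from compound 2 to compound 4 (1.84 log units; beyond the scatter) for the same kind of replacement. Of the features counted, the group's ring changes and its hydrogen-bond donor disappears, but no available measurement shows why the number rises so sharply.

Still open, going by these compounds, is whether the ring or the missing donor accounts for the rise, since both change together here. A dimethylamino group or a pyrrolidine ring in the same place would help separate these two changes.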